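A few compounds are considered here, and "the series" means these few. Any claim that something is new, unique, unknown or untested is made for them only; others in the source may bear on it.

Working notes on the series. All compounds share one core and are varied in the aryl group carried on an aromatic carbon. Compound 1 `c1cnc(-c2ccccc2OCC2=NCCN2)nc1` was run in a functional assay for activation of Alpha-1D adrenergic receptor (Homo sapiens), read by calcium flux; on this read-out lower numbers stand for an effect already at smaller amounts and higher numbers for an effect only at larger amounts of compound; for compound 1 the result is only a limit of the assay, < 100000 nM. Compound 2 `c1ccc(-c2ccncn2)c(OCC2=NCCN2)c1` likewise gives only a limit, < 100000 nM. Among the compounds with values here, compound 3 `c1c[nH]c(-c2ccccc2OCC2=NCCN2)c1` is the one compound with a number, reaching 6.31 nM in this assay. Compound 3 stands alone on the shown values, as two of three results sit at the limit (the limit of < 100000 nM in this assay, at which 2 of the 3 values shown sit). Among the measured compounds, a step that the two limits leave unreadable from compound 1 to compound 2, a step that the limit leaves unreadable from compound 1 to compound 3 and a step that the limit leaves unreadable from compound 2 to compound 3 all remain without a readable size. Compound 4 `c1ccc(-c2ccoc2)c(OCC2=NCCN2)c1` is not yet measured and differs from compound 3 by furan-3-yl in place of 1H-pyrrol-2-yl on an aromatic carbon. Within the data shown here, no measured step covers this change, so no size can be borrowed from the series. Compound 4 is expected in this assay at roughly 150 nM, with a range from 15 nM to 1500 nM. The expected step is a 24-fold higher number from compound 3 to compound 4 (1.38 log units; beyond the scatter), a loss of potency of uncertain extent.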

Compound 4, half-maximal effective concentration: 5.01 nM
Compound 4: middle estimate off by 30-fold (1.48 log units), on the high side; measured number outside the range, below it.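

Within the data shown here, for the first time at this position, two aryl groups can be compared by number in this assay. Furan-3-yl in place of 1H-pyrrol-2-yl gives a 1.3-fold lower number from compound 3 to compound 4 (0.10 log units; within the scatter). This change removes the hydrogen-bond donor of the leaving group and brings in a hydrogen-bond acceptor, so among these two compounds a number in the low range does not depend on that donor.

From the compounds shown here alone, the steps from compound 1 and compound 2 to compound 4 cannot be read, and the two pyrimidinyl groups stay uncompared with the five-membered rings, since their results are limits and not numbers: the limit of < 100000 nM in this assay, at which 2 of the 4 values shown sit. Also open is whether the match between compound 3 and compound 4 extends to thiophen-3-yl, to a plain phenyl, or to a group carrying an amine at this place.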